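A Smaller Aryl Group and the Expected Cell Toxicity

The compounds below may be only part of what the source reports. "The series", "measured", "known", "first", "only" and "open" are said of these compounds alone.

Compound 1 `COC(=O)c1ccc(NCc2cncn2Cc2ccccc2-c2ccccc2)cc1-c1ccccc1`: "not determined" (no result reported)
Compound 2 `c1ccc(-c2ccc(Cn3cncc3CNc3ccc(-c4nc5ccccc5s4)c(-c4ccccc4)c3)cc2)cc1`: > 1000 nM

Two compounds from this series have so far been looked at in a toxicity assay on NIH3T3 cells (Mus musculus) for cytotoxicity, read by resazurin assay; a higher number here means that more compound is needed for the effect, a lower number that less compound is needed. For compound 1 the outcome recorded is "not determined" (no result reported), so compound 1 stands on no number of its own in this assay. Compound 2 reached only a limit of the assay, namely > 1000 nM. Among the compounds with values here, the one piece of evidence at hand is therefore (the limit of > 1000 nM in this assay, at which 1 of the 2 values shown sits).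

Compound 3 `COC(=O)c1ccc(NCc2cncn2Cc2cccc(Cl)c2)cc1-c1ccccc1` has not yet been measured. It differs from compound 1 in one place: 3-chlorophenyl in place of 2-phenylphenyl on a saturated chain carbon bound to an aromatic nitrogen. Within the data shown here, since compound 1 carries no value, and no step between measured compounds exists, the size of the step from compound 1 to compound 3 in this assay cannot be read from the data; the account expects no change beyond the usual scatter in either direction. On that footing compound 3 is estimated to give 5000 nM in this assay. The expected range for compound 3 runs from 1000 nM to 30000 nM, and a limit reading rather than a number is considered likely.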

Compound 3, half-maximal effective concentration: > 10000 nM
Compound 3: no number, only a limit; the forecaster's own chance of this, stated with the estimate: 65%; middle value at least 2.0-fold (0.30 log units) away from the limit.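

Within the data shown here, no step from compound 1 to compound 3 can be read in this assay, as compound 1 carries no number there. Compound 3 gives only a limit of the assay, > 10000 nM. The compounds shown leave open how far 3-chlorophenyl in place of 2-phenylphenyl shifts the half-maximal effective concentration, or in which direction.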